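The source may hold more compounds than are shown below. What is called first, only, known or untested is meant among the compounds shown, and "the series" means these compounds.

Measured so far in a physicochemical assay for lipophilicity; a lower number here means a more polar compound, a higher number a more lipophilic compound:
Compound 1, `NS(=O)(=O)Oc1ccc2c(c1)CN(C(=O)c1ccc(N3CCN(Cc4ccccc4)CC3)cc1)CC2`: 1.93
Compound 2, `NS(=O)(=O)Oc1ccc2c(c1)CN(C(=O)c1ccc(N3CCCCC3)cc1)CC2`: 1.93

Compound 2 stands level with compound 1 at the digits shown; its nearest neighbour is compound 1, and the two do not differ beyond the scatter of this assay. Compound 3 `CCCN(Cc1ccccc1)c1ccc(C(=O)N2CCc3ccc(OS(N)(=O)=O)cc3C2)cc1` has not yet been measured. It differs from compound 2 in one place: benzyl(propyl)amino in place of piperidin-1-yl on an aromatic carbon. For the measured compounds named here, no step between measured compounds is available, so the expectation for compound 3 rests on the change itself rather than on any measured step. The group that enters is larger than the group that leaves, and the counted difference shows no donor and no charge coming in, so an increase in this assay beyond the scatter is expected rather than a decrease or no change. The step from compound 2 to compound 3 is estimated at a number 0.87 log units higher from compound 2 to compound 3 (beyond the scatter). Compound 3 is accordingly expected to give about 2.8 in this assay, within a range from 2.3 to 3.3.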

Compound 3, partition coefficient: 1.93
For compound 3 the middle estimate is 0.87 log units above the measured one; the whole stated range lies above it.
By their numbers in this assay, from the lowest: compounds 1, 2 and 3 (each within the scatter of the next).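

Putting benzyl(propyl)amino in place of piperidin-1-yl on an aromatic carbon, para to a large group, gives no change at the digits printed from compound 2 to compound 3 (within the scatter) in this assay. This pair shows that, at this position, the larger entering group, which brings a six-membered aromatic ring of carbon only and loses the six-membered non-aromatic ring, leaves the reading within the scatter, so for this one change the counted gain in size does not show up in the number. Nothing at hand accounts for this level reading.

The compounds shown leave open whether the same holds for groups of another kind at this position, such as a carboxylic acid or a primary amine, where the counted donors or charge would differ from those of piperidin-1-yl and benzyl(propyl)amino. They also leave open whether a longer chain in place of the propyl, or a substituent such as chlorine on the benzyl ring, would still stay within the scatter of compound 3, since this single step cannot be stretched into a rule for the position.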